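The source may report more compounds than this note shows. Statements on the series, on what has been measured and on what is new or still open speak of the compounds shown alone.

Compound 2 `CC(C(=O)NCc1ccc(C(F)(F)F)nc1NCc1ccc(Cl)cc1)c1ccc(NS(C)(=O)=O)c(F)c1` is the starting point. In a functional assay on CHO-K1 cells for antagonist activity at transient receptor potential cation channel subfamily V member 1 (Homo sapiens), read by FLIPR (on this read-out lower numbers stand for stronger inhibition and higher numbers for weaker inhibition), compound 2 gives 414 nM, the lowest of the two numbers reported so far. Compound 1 `CC(C(=O)NCc1ccc(C(F)(F)F)nc1Nc1ccccc1)c1ccc(NS(C)(=O)=O)c(F)c1` carries a phenyl on the same nitrogen, and in this assay compound 1 gives 1400 nM. Among the measured compounds shown here, the only measured step, a 3.4-fold lower number from compound 1 to compound 2 (0.53 log units; beyond the scatter), is modest. Compound 3 `CC(C(=O)NCc1ccc(C(F)(F)F)nc1NCc1cccnc1)c1ccc(NS(C)(=O)=O)c(F)c1`, which carries yet another group on that nitrogen, is reported in this assay as "not active" (no number reported), with no number given. Compound 4 `CC(C(=O)NCc1ccc(C(F)(F)F)nc1N1CCC(O)CC1)c1ccc(NS(C)(=O)=O)c(F)c1` is not yet measured; it differs from compound 2 as follows: 4-hydroxypiperidin-1-yl in place of (4-chlorobenzyl)amino on an aromatic carbon. For the measured compounds named here, only the step from compound 1 to compound 2 bears directly on a change at this position, and it was modest; compound 3 shows that a different group there can remove measurable activity altogether. The non-aromatic ring that enters in compound 4 is a larger departure than either of those. For compound 4 a weaker result is therefore expected, a step of a 7.2-fold higher number from compound 2 to compound 4 (0.86 log units; beyond the scatter) in this assay. Compound 4 is estimated at 3000 nM, between 800 nM and 12000 nM.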

Compound 4, half-maximal inhibitory concentration: "not active" (no number reported)
No number was reported for compound 4, and the estimate cannot be compared.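

Among the compounds shown here, compound 4 is reported as not active, without a number, so no step from compound 2 to compound 4 can be read. No measurement shown here bears on this result. The compounds shown leave open whether any other group at this position would give a lower number than compound 2.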